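Trimming a Chlorophenyl to Chloro on a Sulfonamide

The compounds below may be only part of what the source reports. "The series", "measured", "known", "first", "only" and "open" are said of these compounds alone.

Compound 1 `CC1CCN(C2CCN(S(=O)(=O)c3cccc(-c4ccc(Cl)cc4)c3)CC2)CC1`: > 5000 nM
Compound 2 `COc1cc(C)ccc1S(=O)(=O)N1CCC(N2CCC(C)CC2)CC1`: > 5000 nM
Compound 3 `COc1ccc(OC)c(S(=O)(=O)N2CCC(N3CCC(C)CC3)CC2)c1`: > 5000 nM

The three measured compounds were tested in an ADME assay on HCT-116 cells (Homo sapiens) for cytotoxicity, read by CellTiter-Glo, with a stated time of 72 h; on this read-out higher numbers stand for weaker inhibition and lower numbers for stronger inhibition. Compound 1 gives only a limit there, not a number. Compound 2 and compound 3 likewise give limits, and all three values sit at the limit of > 5000 nM in this assay, at which 3 of the 3 values shown sit. Among the compounds with values here, compound 1 therefore cannot be placed relative to the others; no step between measured compounds is available.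

Compound 4 `CC1CCN(C2CCN(S(=O)(=O)c3cccc(Cl)c3)CC2)CC1` is unmeasured. It differs from compound 1 by chloro in place of 4-chlorophenyl on an aromatic carbon. Within the data shown here, with no measured step to lean on, the expected change in this assay is none beyond the scatter, and compound 4 is expected to return a limit as well.

The estimate for compound 4 is 20000 nM, with a range from 5000 nM to 100000 nM, which means an expected step that the limit leaves unreadable from compound 1 to compound 4.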

Compound 4, half-maximal inhibitory concentration: > 5000 nM
Compound 4: a limit, no number; the forecaster's own chance of this, stated with the estimate: 85%; the middle value is on the limit's open side.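

Compound 4 gives > 5000 nM as a limit, not a number. In this assay no step can be read between compound 1 and compound 4, as both give only limits: (the limit of > 5000 nM in this assay, at which 4 of the 4 values shown sit). On these data alone, whether chloro in place of 4-chlorophenyl changes the result at all stays open.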